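The source may report more compounds than this note shows. Statements on the series, on what has been measured and on what is new or still open speak of the compounds shown alone.

Measured compounds:
Compound 1, `O=C(O)Cc1sc(C(c2ccc(F)cc2)c2ccc(F)cc2)nc1-c1ccnc(N2CCCC2)c1`: 80%
Compound 2, `O=C(O)Cc1sc(C(c2ccccc2)c2ccc(F)c(F)c2)nc1-c1ccc(F)cc1`: 80%

Both were run in an in vitro functional assay on HEK285-7 cells for antagonist activity at prostaglandin D2 receptor 2 (Homo sapiens), read by BRET and beta-arrestin recruitment; a higher number here means a larger maximal response, a lower number a smaller maximal response. Compound 1 gives 80%, and compound 2 gives 80%; the two values lie within the scatter of each other, so compound 1 stands level with compound 2 on this read-out.

Compound 3, `N#Cc1cc(-c2nc(C(c3ccc(F)cc3)c3ccc(F)cc3)sc2CC(=O)O)ccc1F`, has not yet been measured. It differs from compound 1 in one place: 3-cyano-4-fluorophenyl in place of 2-(pyrrolidin-1-yl)pyridin-4-yl on an aromatic carbon. Within the data shown here, no measured pair shows a change of this kind, so no measured step guides the expectation. The step from compound 1 to compound 3 is expected to be small, none beyond the scatter: no change at the digits printed from compound 1 to compound 3 (within the scatter). Compound 3 is estimated at 80%, within a range of 60% to 95%.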

Compound 3, largest response reached (reported as efficacy), in percent of the reference or control that the assay uses: 80%
For compound 3 middle estimate and measured number coincide at the digits printed; measured number inside the range.
By their numbers in this assay, from the lowest: compounds 1, 2 and 3 (each within the scatter of the next).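

At the aromatic carbon next to the ring nitrogen, 3-cyano-4-fluorophenyl in place of 2-(pyrrolidin-1-yl)pyridin-4-yl gives no change at the digits printed from compound 1 to compound 3 (within the scatter) in this assay. This position therefore carries either a pyridine ring with a pyrrolidine ring attached or a carbon-only ring with a nitrile and a fluorine, with the read-out level between them. No supporting data explain this lack of change. From the compounds shown here alone, whether a methyl group or an open-chain amine at this position would also leave the response level remains open.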